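Swapping Hydroxy for Difluoro on the Amide Piperidine

A few compounds are considered here, and "the series" means these few. Any claim that something is new, unique, unknown or untested is made for them only; others in the source may bear on it.

Measured compounds:
compound 1, `CCN(CC)S(=O)(=O)c1ccc(S(=O)(=O)N2CCC[C@@H](C(=O)N3CCC(O)CC3)C2)cc1`: 230 nM
compound 2, `O=C([C@@H]1CCCN(S(=O)(=O)c2ccc(S(=O)(=O)C3CCC3)cc2)C1)N1CCC(F)(F)CC1`: 12.6 nM
compound 3, `CC(C)S(=O)(=O)c1ccc(S(=O)(=O)N2CCC[C@@H](C(=O)N3CCC(F)(F)CC3)C2)cc1`: 9.1 nM

In a functional assay on MIA PaCa-2 cells (Homo sapiens) for inhibition, read by MTT assay, with a stated time of 3 days (a lower number here means a stronger inhibitor, a higher number a weaker inhibitor), compound 1 gives 230 nM, the highest of the three numbers and therefore the weakest inhibitor among them, since its gaps to compound 2 and compound 3 both lie beyond the usual scatter. Compound 4, `CCN(CC)S(=O)(=O)c1ccc(S(=O)(=O)N2CCC[C@@H](C(=O)N3CCC(F)(F)CC3)C2)cc1`, differs from compound 1 in one place: 4,4-difluoropiperidin-1-yl in place of 4-hydroxypiperidin-1-yl on a carbonyl carbon.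

Going by the values given here, the only measured step, a 1.4-fold lower number from compound 2 to compound 3 (0.14 log units; within the scatter), concerns a sulfonyl substituent rather than the amide piperidine and lies within the scatter, so it does not speak to this change. Among the compounds with values here, no measured pair isolates the change from compound 1 to compound 4. What can be said is that compound 2 and compound 3, which both carry the 4,4-difluoropiperidin-1-yl group while also differing from compound 1 elsewhere, give much lower numbers than compound 1 in this assay.

On that basis compound 4 is expected to show a lower number than compound 1, a step of about a 12-fold lower number from compound 1 to compound 4 (1.06 log units; beyond the scatter). The estimate for compound 4 is 20 nM, with a range from 6 nM to 70 nM.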

Compound 4, half-maximal inhibitory concentration: 19 nM
For compound 4 the middle estimate is 1.1-fold (0.02 log units) above the measured one; low and high end bracket the measured number.
By their numbers in this assay, from the lowest: compounds 3, 2 and 4 (each within the scatter of the next, the first and the last beyond it); then compound 1.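

In this assay, going by these compounds alone, a 12-fold lower number from compound 1 to compound 4 (1.08 log units; beyond the scatter) gives the first direct reading of 4,4-difluoropiperidin-1-yl in place of 4-hydroxypiperidin-1-yl on a carbonyl carbon, with the rest of the molecule unchanged, and this step is large. With the 4,4-difluoropiperidin-1-yl group held fixed, changing the group on the sulfonyl sulfur does much less: a 2.1-fold higher number from compound 3 to compound 4 (0.32 log units; beyond the scatter) for diethylamino in place of isopropyl is modest, and a 1.5-fold higher number from compound 2 to compound 4 (0.18 log units; within the scatter) for diethylamino in place of cyclobutyl stays within the usual scatter. Nothing measured here explains why the amide piperidine change has so large an effect.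

Going by these compounds, the hydroxy-to-difluoro step is read only with diethylamino on the sulfonyl sulfur, so its size with isopropyl or cyclobutyl there remains open. Also open, on these data alone, is where a 4-fluoropiperidin-1-yl, 4-methoxypiperidin-1-yl or morpholine amide would fall.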